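A few compounds are considered here, and "the series" means these few. Any claim that something is new, unique, unknown or untested is made for them only; others in the source may bear on it.

Compound 1 `CCOC(=O)Nc1cc(NC(C)CCCN(CC)CC)c2nc(CC)c(CC)nc2n1` gives > 40000 nM in an ADME assay on Vero cells (Chlorocebus sabaeus) for cytotoxicity, read by CellTiter-Glo, with a stated time of 72 h (a lower number here means that less compound is tolerated, a higher number that more compound is tolerated), which is a limit of the assay and not a number.
Compound 2 `CCOC(=O)Nc1cc(NCCCCN(CC)CC)c2nc(-c3cccs3)c(-c3cccs3)nc2n1` gives > 40000 nM in this assay, again a limit rather than a number.

Both measured members of the series thus sit at one place: the limit of > 40000 nM in this assay, at which 2 of the 2 values shown sit. For the measured compounds named here, compound 2 stands nowhere distinct on these numbers; its value is a limit, and the only other value shown is the same limit, so the two cannot be ordered against each other, and no difference in tolerated concentration between them can be read.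

Compound 3 `CCOC(=O)Nc1cc(NCCN(C)C)c2nc(-c3cccs3)c(-c3cccs3)nc2n1` is not yet measured in this assay. It keeps the core of compound 2 and differs in one place: dimethylamino in place of 2-(diethylamino)ethyl on a saturated chain carbon, two bonds along the chain from a nitrogen on an aromatic ring. Going by the values given here, no step between measured compounds with a change of this kind is available, so nothing measured speaks to its size. Given (the limit of > 40000 nM in this assay, at which 2 of the 2 values shown sit), the expected step of a number no higher from compound 2 to compound 3 (the limit leaves the size open) is none beyond the scatter. Compound 3 is therefore estimated at 40000 nM, with a range from 20000 nM to 80000 nM, and is expected most likely to be reported again only as a limit.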

Compound 3, half-maximal cytotoxic concentration: 1600 nM
Compound 3: middle estimate off by 25-fold (1.40 log units), on the high side, outside the stated range (below it).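

In this assay, replacing 2-(diethylamino)ethyl with dimethylamino on a saturated chain carbon, two bonds along the chain from a nitrogen on an aromatic ring, gives an at least 25-fold lower number from compound 2 to compound 3 (1.39 log units; beyond the scatter), the first sign that this side chain can change how much compound the cells tolerate while the core of compound 2 stays the same. Compound 2 gives > 40000 nM, which is a limit and not a number. The size of the step is therefore only a lower bound, and its true size remains unknown because compound 2 sits at the limit: the limit of > 40000 nM in this assay, at which 2 of the 3 values shown sit.

The single change also shortens 4-(diethylamino)butyl to 2-(dimethylamino)ethyl, so the chain and the alkyl groups on the terminal amine change together, and the compounds shown do not separate the two. Going by these compounds, a (4-(dimethylamino)butyl)amino or a (2-(diethylamino)ethyl)amino side chain on the same core would separate them, and whether the same change acts in the same way on a core carrying the two ethyl groups of compound 1 also remains open.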